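This account rests on a few compounds, and the source may have more. Where it says the series, first, only, none or still open, it means among the compounds named here.

Compound 1 `Cc1cccc(C)c1NC(=O)Nc1ccncc1` is measured in a functional assay on the whole organism with Mus musculus as the target, in the maximal electroshock model, with a stated time of 30 min (on this read-out higher numbers stand for an effect only at larger amounts of compound and lower numbers for an effect already at smaller amounts), at 30 mg/kg. Compound 2 `Cc1cccc(Cl)c1NC(=O)Nc1ccncc1` gives 30 mg/kg in this assay, so the step of no change at the digits printed from compound 1 to compound 2 (within the scatter) accompanies chloro in place of methyl on an aromatic carbon. Compound 3 `COc1cc(C)c(NC(=O)Nc2ccncc2)c(C)c1` reaches only a limit of this assay, > 300 mg/kg. The step of an at least 10-fold higher number from compound 1 to compound 3 (1.00 log units; beyond the scatter) goes with methoxy in place of hydrogen on an aromatic carbon, one value sitting at the limit of > 300 mg/kg in this assay, at which 1 of the 3 values shown sits. Compound 1 thus stands level with compound 2 and clear of the limit of compound 3. Compound 4 `Cc1cccc(C)c1NC(=O)Nc1ccccn1` differs from compound 1 by pyridin-2-yl in place of pyridin-4-yl on an amide-type nitrogen. For the measured compounds named here, neither measured step touches the pyridin-4-yl, so no direct precedent exists. Compound 4 is expected to stay near compound 1, with the step of a 2.0-fold higher number from compound 1 to compound 4 (0.30 log units; within the scatter) estimated as small. For compound 4 the estimate in this assay is 60 mg/kg, within 20 mg/kg to 300 mg/kg.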

Compound 4, minimum effective dose: 300 mg/kg
Estimate against measurement, compound 4: 5.0-fold (0.70 log units) below; the measured number falls inside the stated range.
By their numbers in this assay, from the lowest: compounds 1 and 2 (each within the scatter of the next); then compound 4.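

Pyridin-2-yl in place of pyridin-4-yl on an amide-type nitrogen gives a 10-fold higher number from compound 1 to compound 4 (1.00 log units; beyond the scatter) in this assay, the first reading at this position. The two groups have the same atoms and the same counts of donors and acceptors, so those counts alone do not set the read-out here. Compound 4 gives a number and not a limit, and the only limit shown lies elsewhere: the limit of > 300 mg/kg in this assay, at which 1 of the 4 values shown sits.

From the compounds shown here alone, whether pyridin-3-yl or plain phenyl at this place would stay level with compound 1 remains open. The reading rests on one step.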